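Pyridin-2-yl Replacing 2-Aminophenyl on the Alkyne

The source may hold more compounds than are shown below. What is called first, only, known or untested is meant among the compounds shown, and "the series" means these compounds.

Three compounds with a shared core carry different aryl groups on the triple-bonded carbon. Compound 1 `COC(=O)c1sc2cc(C#Cc3ccc(OC)cc3)cnc2c1N` gives 460 nM in a functional assay on MCF7 cells (Homo sapiens) for inhibition, read by sulforhodamine B assay, with a stated time of 48 h; on this read-out lower numbers stand for stronger inhibition of growth and higher numbers for weaker inhibition of growth. Compound 2 `COC(=O)c1sc2cc(C#Cc3ccccc3N)cnc2c1N` gives 4100 nM, and compound 3 `COC(=O)c1sc2cc(C#Cc3ccc(N(C)C)cc3)cnc2c1N` gives 20600 nM. Compound 2 thus stands second highest of the three numbers, with an 8.9-fold higher number from compound 1 to compound 2 (0.95 log units; beyond the scatter) and a smaller gap to compound 3.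

The unmeasured compound 4 `COC(=O)c1sc2cc(C#Cc3ccccn3)cnc2c1N` differs from compound 2 by pyridin-2-yl in place of 2-aminophenyl on a triple-bonded carbon. Within the data shown here, no measured step exchanges a 2-aminophenyl for a pyridin-2-yl, so only the two steps from compound 1 bear on it indirectly: the modest 8.9-fold higher number from compound 1 to compound 2 (0.95 log units; beyond the scatter) and the large 45-fold higher number from compound 1 to compound 3 (1.65 log units; beyond the scatter). Both show that the group on the triple-bonded carbon moves this read-out well beyond the scatter, with compound 1 at the low end and compound 3 at the high end. The change to pyridin-2-yl removes the hydrogen-bond donor of compound 2 while keeping one acceptor, and in the absence of a directly comparable pair a small move toward compound 1 is the most that can be expected.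

Compound 4 is therefore estimated at 2500 nM, with a range from 600 nM to 10000 nM, which is expected to mean a 1.6-fold lower number from compound 2 to compound 4 (0.21 log units; within the scatter).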

Compound 4, concentration for 50% growth inhibition: 37400 nM
The estimate for compound 4 lay 15-fold (1.17 log units) below the measured number, and the stated range ends below it.
By their numbers in this assay, from the lowest: compound 1; then compound 2; then compounds 3 and 4 (each within the scatter of the next).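

In this assay, the step on the triple-bonded carbon that replaces 2-aminophenyl with pyridin-2-yl is a 9.1-fold higher number from compound 2 to compound 4 (0.96 log units; beyond the scatter): an exchange that leaves the hydrogen-bond donor count at zero and the acceptor count unchanged is enough to move the read-out well beyond the scatter, toward weaker inhibition of growth. Set against the 4-methoxyphenyl group, the same replacement gives an 81-fold higher number from compound 1 to compound 4 (1.91 log units; beyond the scatter), and compound 4 now stands with compound 3 at the high end of the series, the two within the scatter of each other, so the high numbers at this position are not confined to the dimethylamino group of compound 3. Nothing available here accounts for the size of this step.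

The compounds shown leave open whether the step from compound 2 to compound 4 follows the loss of the amine or the entry of the ring nitrogen, a question that a plain phenyl group on the triple-bonded carbon could help to separate. They also leave open how pyridin-4-yl or 4-aminophenyl would read at this position.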